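From a Methylphenyl to a Pyrimidinyl Group on the Core

This account rests on a few compounds, and the source may have more. Where it says the series, first, only, none or still open, it means among the compounds named here.

Going by the values given here, compound 1 `Cc1nc2c(cnn2-c2ccccc2)c(=O)n1-c1ccc(OC(F)(F)F)cc1` and compound 2 `Cc1cccc(-n2ncc3c(=O)n(-c4ccc(Cl)cc4)c(C)nc32)c1` share the same fused core and are the only two members of this set with a measurement. In an in vitro functional assay on cells for antagonist activity at metabotropic glutamate receptor 5 (Homo sapiens), read by FLIPR and calcium flux (on this read-out higher numbers stand for weaker inhibition and lower numbers for stronger inhibition), compound 1 reaches only the limit of the method, > 100000 nM, which is not a number but the point past which the test cannot see. Compound 2 also gives only a limit in this assay, > 100000 nM. Among the compounds with values here, both values therefore rest at the limit of > 100000 nM in this assay, at which 2 of the 2 values shown sit, so nothing yet shows any difference in potency between the two, and no step between measured compounds can be drawn.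

Compound 3 `Cc1nc2c(cnn2-c2cncnc2)c(=O)n1-c1ccc(Cl)cc1` is the compound still to be tested. It differs from compound 2 in one place: pyrimidin-5-yl in place of 3-methylphenyl on an aromatic nitrogen. Within the data shown here, no measured pair shows what such a change does on this core. With compound 2 sitting at the limit, the step of a number no higher from compound 2 to compound 3 (the limit leaves the size open) is expected to be none beyond the scatter, and compound 3 is expected to return 100000 nM, most likely again as a limit, within a range from 20000 nM to 300000 nM.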

Compound 3, half-maximal inhibitory concentration: > 100000 nM
Compound 3: a limit, no number; the forecaster's own chance of this, stated with the estimate: 70%; the middle value sits exactly at the limit.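

Compound 3, like compound 2, gives only a limit in this assay, so no step can be read between compound 2 and compound 3, and swapping 3-methylphenyl for pyrimidin-5-yl shows no readable effect: the limit of > 100000 nM in this assay, at which 3 of the 3 values shown sit. The compounds shown leave open whether any compound on this shared core gives measurable inhibition in this assay, and what either group does to potency.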